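Methoxy in place of fluoro on compound 3

A few compounds are considered here, and "the series" means these few. Any claim that something is new, unique, unknown or untested is made for them only; others in the source may bear on it.

Measured so far in a functional assay on HeLa cells (Homo sapiens) for inhibition, read by sulforhodamine B assay; a lower number here means a stronger inhibitor, a higher number a weaker inhibitor
compound 1 `O=C1C(Nc2ccc(I)cc2)=CC(=O)c2c1nc1n2[C@H]2OC[C@@H](O)[C@H]2OC1` gives 4010 nM
compound 2 `O=C1C(Nc2ccccc2F)=CC(=O)c2c1nc1n2[C@H]2OC[C@@H](O)[C@H]2OC1` gives 9820 nM
compound 3 `O=C1C=C(Nc2ccccc2F)C(=O)c2c1nc1n2[C@H]2OC[C@@H](O)[C@H]2OC1` gives 5120 nM

Compound 3 sits within the scatter of compound 1 and of compound 2, while those two stand apart by more than the scatter. Compound 4 `COc1ccccc1NC1=CC(=O)c2nc3n(c2C1=O)[C@H]1OC[C@@H](O)[C@H]1OC3` is still unmeasured. Its change from compound 3 is methoxy in place of fluoro on an aromatic carbon with methoxy in place of fluoro on an aromatic carbon, ortho to a large group.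

For the measured compounds named here, no measured pair makes this exact swap. Going by the values given here, one measured step bears on it, 2-fluorophenyl in place of 4-iodophenyl on an amine nitrogen, which gives a 2.4-fold higher number from compound 1 to compound 2 (0.39 log units; beyond the scatter) and is modest. With compound 3 at 5120 nM as the starting point and the size of that step as the guide, a small step or none beyond the scatter is expected in this assay and no direction is favoured. The estimated step is a 1.0-fold lower number from compound 3 to compound 4 (0.01 log units; within the scatter) and nothing more is read into it. Compound 4 is expected at 5000 nM with an estimated range of 2200 nM to 11000 nM as the expected span.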

Compound 4, half-maximal inhibitory concentration: 2950 nM
For compound 4 the middle estimate is 1.7-fold (0.23 log units) above the measured one; low and high end bracket the measured number.
By their numbers in this assay, from the lowest: compounds 4, 1, 3 and 2 (each within the scatter of the next, the first and the last beyond it).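

In this assay the swap of fluoro for methoxy on an aromatic carbon, ortho to a large group, gives a 1.7-fold lower number from compound 3 to compound 4 (0.24 log units; within the scatter) and so stays inside the scatter. For the compounds shown here, the earlier step (a 2.4-fold higher number from compound 1 to compound 2 (0.39 log units; beyond the scatter)) changed both the substituent and its place on the phenyl ring, whereas here (2-fluorophenyl)amino becomes (2-methoxyphenyl)amino, so this is the first reading of the group at this one position, and methoxy is tolerated there as well as fluoro. No measurement on hand offers an explanation for this reading.

Going by these compounds, whether an amine, a carboxylic acid or a longer chain such as ethoxy on this same carbon would move the number beyond the scatter stays open. Also open, on these data alone, is whether the swap from fluoro to methoxy reads the same on the core arrangement of compound 2.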